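The source may report more compounds than this note shows. Statements on the series, on what has been measured and on what is new or still open speak of the compounds shown alone.

In a functional assay on a cell-free system (Platelet, plasma, Homo sapiens) for inhibition, read by turbidimetry, with a stated time of 3 min (on this read-out lower numbers stand for stronger inhibition and higher numbers for weaker inhibition), compound 1 (`COc1ccc(-n2nc(C(=O)N3CCCCC3)cc2-c2ccc(Cl)cc2)nn1`) gives 41 nM, the lowest of the numbers available, while compound 2 (`O=C(c1cc(-c2ccc(Cl)cc2)n(-c2ccc(=O)[nH]n2)n1)N1CCCCC1`) gives 2090 nM. Compound 3 (`COc1ccc(-n2nc(C(=O)N3CCCCC3)cc2C)nn1`) gives > 10000 nM, which is a limit of the assay and not a number. Compound 4 (`COc1ccc(-n2nc(CCC(=O)N3CCCCC3)cc2-c2ccc(Cl)cc2)nn1`) has not yet been measured. It differs from compound 1 in one place: 2-((piperidin-1-yl)carbonyl)ethyl in place of (piperidin-1-yl)carbonyl on an aromatic carbon. A 2-((piperidin-1-yl)carbonyl)ethyl group stands in place of (piperidin-1-yl)carbonyl on an aromatic carbon, two ring bonds from the ring atom that bears the 4-chlorophenyl group.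

Among the compounds with values here, no measured compound carries a change at this place, so the available steps bear on it only indirectly. Two steps start from compound 1, a 51-fold higher number from compound 1 to compound 2 (1.71 log units; beyond the scatter) and an at least 240-fold higher number from compound 1 to compound 3 (2.38 log units; beyond the scatter), and both are large and lie elsewhere on the core of compound 1. Both single changes led to a higher number, so a sizeable step to a higher number is expected in this assay here too, though this rests on those two steps alone. The expected step is a 20-fold higher number from compound 1 to compound 4 (1.29 log units; beyond the scatter). For compound 4 the estimated value is 800 nM, with an expected range from 120 nM to 6000 nM.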

Compound 4, half-maximal inhibitory concentration: 920 nM
For compound 4 the middle estimate is 1.2-fold (0.06 log units) below the measured one, within the range that was stated.
By their numbers in this assay, from the lowest: compound 1; then compound 4; then compound 2. At a limit, above all of these: compound 3.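

Within the data shown here, with compound 4, this position on the five-membered aromatic ring has a step of its own for the first time: 2-((piperidin-1-yl)carbonyl)ethyl in place of (piperidin-1-yl)carbonyl gives a 22-fold higher number from compound 1 to compound 4 (1.35 log units; beyond the scatter). The entering group keeps the carbonyl and the six-membered non-aromatic ring, and the counts of hydrogen-bond donors and acceptors are unchanged, so a large step in this assay arises here even though those counts stay the same. The limit is held by compound 3 alone, and it is a limit and not a number, so this change leaves compound 4 with a measured value, unlike the swap of 4-chlorophenyl for methyl: the limit of > 10000 nM in this assay, at which 1 of the 4 values shown sits.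

The compounds shown leave open whether a shorter methylene link or a longer chain between the ring and the carbonyl would give a smaller or a larger step, since only the 2-carbonylethyl group stands for any extended chain here. They also leave open how a carboxylic acid, an amine or a morpholine ring in place of the piperidine amide would read at this position.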